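The source may hold more compounds than are shown below. What is called first, only, known or untested is meant among the compounds shown, and "the series" means these compounds.

Measured compounds:
compound 1 `Cc1cn(-c2cc(NC(=O)c3ccc(C)c(Nc4nccc(-c5ccccc5)n4)c3)cc(N3CCNCC3)c2)cn1` — 3.74 L/kg
compound 2 `Cc1cn(-c2cc(CCS(N)(=O)=O)cc(NC(=O)c3ccc(C)c(Nc4nccc(-c5ccccc5)n4)c3)c2)cn1` — 1.72 L/kg
compound 3 `Cc1cn(-c2cc(NC(=O)c3ccc(C)c(Oc4ccccc4)c3)cc(C(F)(F)F)c2)cn1` — 1.69 L/kg

In an ADME assay on the whole organism (Mus musculus, strain CD1) for pharmacokinetics, read by LC-MS, using cassette dosing, with a stated time of 24 h, at a dose of 0.4 mg/kg by the intravenous route (a higher number here means that more of the compound sits outside the plasma, a lower number that more of the compound stays in the plasma), compound 3 gives the lowest of the three numbers. Compound 2 sits within the scatter of compound 3, while compound 1 stands well above both. Compound 4 `Cc1cn(-c2cc(NC(=O)c3ccc(C)c(Oc4ccccc4)c3)cc(N3CCN(C)CC3)c2)cn1` is not yet measured; it differs from compound 3 by 4-methylpiperazin-1-yl in place of trifluoromethyl on an aromatic carbon, placed on an aromatic carbon of a six-membered aromatic ring of carbon only, meta to a 4-methyl-1H-imidazol-1-yl group and meta to a large group.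

Going by the values given here, the one step that bears on this change is a 2.2-fold lower number from compound 1 to compound 2 (0.34 log units; beyond the scatter), where removing a piperazin-1-yl ring from the shared core lowered the number by a modest but real margin. Compound 4 reintroduces a piperazine-type ring in place of trifluoromethyl, so a rise in this assay is expected for compound 4, of about the size seen in that step, a 2.1-fold higher number from compound 3 to compound 4 (0.32 log units; beyond the scatter). The value for compound 4 is therefore estimated at 3.5 L/kg, with a likely range from 2 L/kg to 6 L/kg.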

Compound 4, volume of distribution at steady state: 9.26 L/kg
Beside the measured number, compound 4's estimate is 2.6-fold (0.42 log units) below it; measured number above the stated range.
By their numbers in this assay, from the lowest: compounds 3 and 2 (each within the scatter of the next); then compound 1; then compound 4.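

In this assay, 4-methylpiperazin-1-yl in place of trifluoromethyl on this aromatic carbon gives a 5.5-fold higher number from compound 3 to compound 4 (0.74 log units; beyond the scatter), placing compound 4 at the top of the four compounds. The earlier step, a 2.2-fold lower number from compound 1 to compound 2 (0.34 log units; beyond the scatter), belongs to another shared core and another pair of groups; the new step shows that on the core of compound 3 this position alone can also shift the number beyond the scatter. Nothing available explains the size of this shift.

Open, going by these compounds, is how the step divides between the ring and its methyl group: piperazin-1-yl, morpholin-4-yl or an open-chain amine such as dimethylamino on this carbon would separate the two. Also open, on these data alone, is whether trifluoromethyl and 4-methylpiperazin-1-yl give a step of similar size on the core of compound 1.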